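Formyl removal in an allyl-substituted antiproliferative series

The source may report more compounds than this note shows. Statements on the series, on what has been measured and on what is new or still open speak of the compounds shown alone.

Compound 1 `C=CCc1cc(C=O)c(OCC(=O)OCC)c(-c2ccc(OCC(=O)OCC)c(CC=C)c2)c1` gives > 85800 nM, which is a limit of the assay.
Compound 2 `C=CCc1ccc(OCC(=O)OCC)c(-c2ccc(OCC(=O)OCC)c(CC=C)c2)c1` gives > 91300 nM, which is a limit of the assay.
Compound 3 `C=CCc1cc(C=O)c(OCC)c(-c2ccc(OCC)c(CC=C)c2)c1` gives 39000 nM.

All values come from a functional assay on A549 cells (Homo sapiens) for antiproliferative activity, read by MTT assay, with a stated time of 24 h; on this read-out higher numbers stand for weaker inhibition and lower numbers for stronger inhibition. Compound 2 differs from compound 1 by hydrogen in place of formyl on an aromatic carbon. The step that the two limits leave unreadable from compound 1 to compound 2 cannot be sized, since both ends sit at a limit: the limit of > 85800 nM in this assay, at which 1 of the 3 values shown sits, and (the limit of > 91300 nM in this assay, at which 1 of the 3 values shown sits). Among the compounds with values here, compound 3 is therefore the only compound in this assay with a number rather than a limit. The difference between the cores of compound 1 and compound 3 is not broken down here.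

Compound 4 `C=CCc1ccc(OCC)c(-c2ccc(OCC)c(CC=C)c2)c1` has not yet been measured. It differs from compound 3 by hydrogen in place of formyl on an aromatic carbon. Within the data shown here, this is the same kind of change as the one from compound 1 to compound 2, but not the same: in compound 4 the place is ortho to an ethoxy group, whereas in compound 2 it is ortho to a (ethoxycarbonyl)methoxy group.

Among the measured compounds shown here, because compound 3 gives 39000 nM and the only comparable step is unreadable, the step expected for compound 4 is a 1.5-fold higher number from compound 3 to compound 4 (0.19 log units; within the scatter), a modest loss at most. Compound 4 is thus estimated at 60000 nM, expected between 25000 nM and 150000 nM, with a real chance that this assay again reports only a limit.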

Compound 4, half-maximal inhibitory concentration: > 124000 nM
Compound 4: a limit, no number (the forecaster's own chance of this, stated with the estimate: 40%); middle value at least 2.0-fold (0.31 log units) from the limit.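

In this assay, hydrogen in place of formyl on an aromatic carbon, ortho to an ethoxy group, gives an at least 3.1-fold higher number from compound 3 to compound 4 (0.50 log units; beyond the scatter), so on the core of compound 3 the formyl group cannot be lost without a readable drop in activity. As far as these compounds go, compound 4 gives > 124000 nM, which is a limit of the assay, and the full size of the step therefore stays unknown. The same change from compound 1 to compound 2 cannot be read, with limits at both ends, so the loss is shown on one core only and nothing shows whether it carries over to the core with (ethoxycarbonyl)methoxy groups.

Open, from the compounds shown here alone, is whether another group in the formyl place, such as a carboxylic acid or an amine, would keep or improve on compound 3 at 39000 nM. Also open, going by these compounds, is how a longer chain in place of the ethoxy groups would behave with and without the formyl group.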